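Tert-butyl for difluorophenyl on the alkyne of compound 2

A few compounds are considered here, and "the series" means these few. Any claim that something is new, unique, unknown or untested is made for them only; others in the source may bear on it.

Within the data shown here, compound 1 `CC(=O)OCC(CCn1cc(C#CC(C)(C)C)c(=O)n(C(=O)c2ccccc2)c1=O)COC(C)=O` is the only member of this small set with a number: in an ADME assay on BJ cells (Homo sapiens) for antiproliferative activity, read by MTT assay, with a stated time of 72 h (on this read-out lower numbers stand for stronger inhibition and higher numbers for weaker inhibition), compound 1 gives 36900 nM. Compound 2 `O=c1[nH]c(=O)n(CCC(CO)CO)cc1C#Cc1cc(F)cc(F)c1` stands apart on the read-out. In this assay compound 2 reaches only the limit of > 100000 nM, which is a limit of the assay and not a measured number, as shown by the limit of > 100000 nM in this assay, at which 1 of the 2 values shown sits. Compound 3 `CC(C)(C)C#Cc1cn(CCC(CO)CO)c(=O)[nH]c1=O` is not yet measured. It differs from compound 2 by tert-butyl in place of 3,5-difluorophenyl on a triple-bonded carbon. Among the measured compounds shown here, with compound 2 sitting at the limit, no measured step bounds the change, and the expectation for the step from compound 2 to compound 3 is an at least 1.2-fold lower number from compound 2 to compound 3 (0.09 log units; that floor lies within the scatter), a move that is expected to stay within the scatter or to fall short of the limit only slightly. Compound 3 is therefore estimated at 80000 nM, within a range from 25000 nM to 300000 nM.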

Compound 3, half-maximal inhibitory concentration: 58200 nM
Compound 3: the middle estimate sits 1.4-fold (0.14 log units) above what was measured; low and high end bracket the measured number.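

In this assay, putting tert-butyl in place of 3,5-difluorophenyl on a triple-bonded carbon gives an at least 1.7-fold lower number from compound 2 to compound 3 (0.23 log units; that floor lies within the scatter). Among these compounds, this is the first reading of a change at this position alone, and compound 3 gives a measured number where the group that leaves gave none. How large the change really is cannot be read, because the value of compound 2 is a limit and not a number: the limit of > 100000 nM in this assay, at which 1 of the 3 values shown sits.

The compounds shown leave open how the number would respond to other groups on the triple-bonded carbon, such as cyclopropyl, unsubstituted phenyl or a dimethylamino-bearing chain. They also leave open whether tert-butyl and 3,5-difluorophenyl would differ in the same way on the core of compound 1, which carries acetate esters and a benzoyl group.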